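The source may hold more compounds than are shown below. What is called first, only, known or untested is meant among the compounds shown, and "the series" means these compounds.

Measured in an ADME assay on HepG2 cells (Homo sapiens) for cytotoxicity, read by MTT assay; on this read-out higher numbers stand for weaker inhibition and lower numbers for stronger inhibition:
- compound 1 `O=C(NCc1ccccc1)Oc1ccc(Cl)cc1C(=O)Nc1ccc(F)cc1`: > 125000 nM, a limit
- compound 2 `O=C(Nc1ccccc1)Oc1ccc(Cl)cc1C(=O)Nc1ccc(F)cc1`: > 20000 nM, a limit
- compound 3 `O=C(Nc1ccccc1)Oc1ccc(Cl)cc1`: > 125000 nM, a limit

Compound 1 stands only at a limit, > 125000 nM. That is the limit of > 125000 nM in this assay, at which 2 of the 3 values shown sit. The other limit in the series is the limit of > 20000 nM in this assay, at which 1 of the 3 values shown sits.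

Compound 4 `O=C(NCc1ccccc1)Oc1ccc(Cl)cc1C(=O)Nc1ccc(Br)cc1` differs from compound 1 at one place: bromo in place of fluoro on an aromatic carbon. This is bromo in place of fluoro on an aromatic carbon. Going by the values given here, no measured step makes this change. Among the compounds with values here, the one measured step, a step that the two limits leave unreadable from compound 1 to compound 2, lies elsewhere and offers no size to carry over. No step beyond the scatter is therefore expected in this assay, in either direction, and another limit is likely. The expected change is an at least 1.5-fold lower number from compound 1 to compound 4 (0.19 log units; that floor lies within the scatter). Compound 4 is estimated at 80000 nM, with an expected range of 20000 nM to 200000 nM.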

Compound 4, half-maximal inhibitory concentration: > 50000 nM
Compound 4 gave a limit, no number (the forecaster's own chance of this, stated with the estimate: 80%); the middle value does not contradict the limit.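

Compound 1 and compound 4 both give only limits, not numbers, so the step between them cannot be read. The compounds shown leave open whether bromo in place of fluoro makes any real difference in this assay.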